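A few compounds are considered here, and "the series" means these few. Any claim that something is new, unique, unknown or untested is made for them only; others in the source may bear on it.

Measured in a functional assay on MCF7 cells (Homo sapiens) for antiproliferative activity, read by MTT assay, with a stated time of 72 h; on this read-out lower numbers stand for stronger inhibition and higher numbers for weaker inhibition:
compound 1 `COc1cc(-c2ncnn2-c2cccc(F)c2)cc(OC)c1OC`: > 10000 nM (a limit)
compound 2 `COc1ccc(-c2ncnn2-c2cc(OC)c(OC)c(OC)c2)cc1`: 360 nM
compound 3 `COc1cc(-c2ncnn2-c2ccc([N+](=O)[O-])cc2)cc(OC)c1OC`: > 10000 nM (a limit)

Within the data shown here, compound 2 holds the only true number here, 360 nM. The other two values are limits of the assay, not numbers. Compound 4 `COc1cc(-n2ncnc2-c2ccccc2)cc(OC)c1OC` departs from compound 2 in one place: hydrogen in place of methoxy on an aromatic carbon, so that 4-methoxyphenyl becomes phenyl, with hydrogen in place of methoxy on an aromatic carbon. Among the measured compounds shown here, no measured pair shows this change directly. Neither compound 1 nor compound 3 carries the 4-methoxyphenyl, and both stand at the limit of > 10000 nM in this assay, at which 2 of the 3 values shown sit, though each also differs from compound 2 elsewhere. A clear loss of potency in this assay is therefore expected, an estimated 8.3-fold higher number from compound 2 to compound 4 (0.92 log units; beyond the scatter), which is beyond the scatter. For compound 4 the estimated value is 3000 nM, with an expected range of 700 nM to 10000 nM.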

Compound 4, half-maximal inhibitory concentration: > 10000 nM
Compound 4 ended at the assay's limit (the forecaster's own chance of this, stated with the estimate: 35%); middle value at least 3.3-fold (0.52 log units) from the limit.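

In this assay, the change from 4-methoxyphenyl to phenyl can now be read directly, and it costs much of the activity: an at least 27-fold higher number from compound 2 to compound 4 (1.44 log units; beyond the scatter) is a large step for the loss of one methoxy. The methoxy at this place, para to a large group, therefore matters greatly for compound 2. Compound 4 gives no true number, only a limit of the assay: the limit of > 10000 nM in this assay, at which 3 of the 4 values shown sit.

On these data alone, how far potency truly falls remains unknown. As far as these compounds go, it is also open whether another group at this place, such as an ethoxy or an amine, would keep the activity of compound 2.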